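This account rests on a few compounds, and the source may have more. Where it says the series, first, only, none or still open, it means among the compounds named here.

Compound 2, `COC(=O)NC1CCc2ccc(NC(=O)c3cccc(C)c3-c3ccc(C(F)(F)F)cc3)cc2CC1`: 1.6 nM
Compound 3, `COC(=O)NC1CCc2ccc(NC(=O)c3cc(C)cc(C)c3-c3ccc(C(F)(F)F)cc3)cc2CC1`: 2.4 nM
Compound 1, `Cc1cccc(C(=O)Nc2ccc3c(c2)CC(NS(C)(=O)=O)C3)c1-c1ccc(Cl)cc1`: 6.6 nM

In an assay for inhibition of apolipoprotein B-100 (Homo sapiens), tested at 100 nM (a lower number here means a stronger inhibitor, a higher number a weaker inhibitor), compound 2 holds the lowest of the three numbers, though compound 3 lies within the scatter of it, as a 1.5-fold higher number from compound 2 to compound 3 (0.18 log units; within the scatter) shows, while compound 1 stands further off. Compound 4, `COC(=O)NC1CCc2ccc(NC(=O)c3cccc(C)c3-c3ccc(Cl)cc3)cc2CC1`, differs from compound 2 by chloro in place of trifluoromethyl on an aromatic carbon. Among the measured compounds shown here, no measured step covers this change; the single one-place step, a 1.5-fold higher number from compound 2 to compound 3 (0.18 log units; within the scatter), concerns a methyl group. Compound 1 also carries a chloro group, but it differs from compound 2 in its core too, so its higher number cannot be tied to the chloro alone. The move from compound 2 to compound 4 is therefore expected to be small, a 1.9-fold higher number from compound 2 to compound 4 (0.27 log units; within the scatter). Compound 4 is estimated at 3 nM, in the range 1.2 nM to 8 nM.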

Compound 4, half-maximal inhibitory concentration: 2 nM
Beside the measured number, compound 4's estimate is 1.5-fold (0.18 log units) above it; the measured number falls inside the stated range.
By their numbers in this assay, from the lowest: compounds 2, 4 and 3 (each within the scatter of the next); then compound 1.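

Among the compounds shown here, this is the first one-place step at this position. In this assay, the change from 4-(trifluoromethyl)phenyl to 4-chlorophenyl gives a 1.3-fold higher number from compound 2 to compound 4 (0.10 log units; within the scatter). A single chlorine atom thus takes the place of a group of four heavy atoms while the two numbers stay within the scatter of each other, though this holds only for this one pair on the shared core. Nothing available explains why the two groups read alike. Still open, from the compounds shown here alone, is how a methoxy group, an amine or plain hydrogen would read at this place, and whether chloro and trifluoromethyl also read alike on the core of compound 1.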